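A few compounds are considered here, and "the series" means these few. Any claim that something is new, unique, unknown or untested is made for them only; others in the source may bear on it.

Measured compounds:
compound 1, `CCOC(=O)C1=Cc2ccccc2OC1(OCc1cn(-c2ccc(C)cc2)nn1)C(F)(F)F`: 30200 nM
compound 2, `CCOC(=O)C1=Cc2ccccc2OC1(OCc1cn(CC(=O)Nc2cccc(F)c2)nn1)C(F)(F)F`: > 150000 nM
compound 3, `CCOC(=O)C1=Cc2ccccc2OC1(OCc1cn(-c2cccc(C(F)(F)F)c2)nn1)C(F)(F)F`: > 150000 nM

Three compounds sharing one core were tested in a functional assay on DU-145 cells (Homo sapiens) for inhibition, read by MTT assay, with a stated time of 24 h; a lower number here means a stronger inhibitor, a higher number a weaker inhibitor. Compound 1, bearing a 4-methylphenyl on an aromatic nitrogen, gives 30200 nM. Compound 2 reaches only the limit of > 150000 nM, which is not a number. Compound 3 likewise stands at the limit of > 150000 nM; it is the weaker end of what is shown, because the limit of > 150000 nM in this assay, at which 2 of the 3 values shown sit, is where it sits. The measured steps are an at least 4.9-fold higher number from compound 1 to compound 2 (0.69 log units; beyond the scatter) and an at least 4.9-fold higher number from compound 1 to compound 3 (0.69 log units; beyond the scatter), while a step that the two limits leave unreadable from compound 2 to compound 3.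

The unmeasured compound 4, `CCOC(=O)C1=Cc2ccccc2OC1(OCc1cn(CC(=O)Nc2ccc(I)cc2Cl)nn1)C(F)(F)F`, differs from compound 3 by ((2-chloro-4-iodophenyl)carbamoyl)methyl in place of 3-(trifluoromethyl)phenyl on an aromatic nitrogen. The entering group is of the same ((phenyl)carbamoyl)methyl kind as that of compound 2, which also sits at the limit. Both steps from compound 1 point away from potency, so compound 4 is expected to remain at or beyond the limit, with a step that the limit leaves unreadable from compound 3 to compound 4 estimated as no readable change. Compound 4 is estimated at 200000 nM, in the range 60000 nM to 600000 nM.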

Compound 4, half-maximal inhibitory concentration: 24400 nM
Estimate against measurement, compound 4: 8.2-fold (0.91 log units) above; the whole stated range lies above it.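

Exchanging the 3-fluorophenyl for 2-chloro-4-iodophenyl on the amide-type nitrogen gives an at least 6.1-fold lower number from compound 2 to compound 4 (0.78 log units; beyond the scatter) in this assay, so a ((phenyl)carbamoyl)methyl group on the aromatic nitrogen does not by itself hold a compound at the limit. The change from 3-(trifluoromethyl)phenyl gives an at least 6.1-fold lower number from compound 3 to compound 4 (0.78 log units; beyond the scatter), and both of these steps start from a limit and not from a number: the limit of > 150000 nM in this assay, at which 2 of the 4 values shown sit. Against the 4-methylphenyl group there is a 1.2-fold lower number from compound 1 to compound 4 (0.09 log units; within the scatter), so two different kinds of group on this nitrogen stand level within the scatter.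

The compounds shown leave open whether the chlorine or the iodine of compound 4 carries the step from the 3-fluorophenyl group. They also leave open what an amine or a carboxylic acid on that phenyl ring, or a longer chain in place of the methyl part of the group, would do.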